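From isobutyl to pentyl on a shared core

The compounds below may be only part of what the source reports. "The series", "measured", "known", "first", "only" and "open" are said of these compounds alone.

Of the compounds shown here, three with one shared core have been measured so far in a functional assay on the whole organism for inhibition, with Scenedesmus acutus as the target (on this read-out lower numbers stand for stronger inhibition and higher numbers for weaker inhibition), on whole algal cells. Compound 1 `CCOC(=O)c1cc(N2C(=O)C3=C(CCCC3)C2=O)ccc1Cl` gives 1910 nM and compound 2 `CCCOC(=O)c1cc(N2C(=O)C3=C(CCCC3)C2=O)ccc1Cl` gives 1120 nM while compound 3 `CC(C)COC(=O)c1cc(N2C(=O)C3=C(CCCC3)C2=O)ccc1Cl` gives 977 nM on the same read-out. Compound 3 stands level with the other two: the three numbers lie within the scatter of one another, so no ranking can be drawn.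

Compound 4 `CCCCCOC(=O)c1cc(N2C(=O)C3=C(CCCC3)C2=O)ccc1Cl` has not been measured yet. Its difference from compound 3 is butyl in place of isopropyl on a saturated chain carbon bound to an oxygen next to a carbonyl group with butyl in place of isopropyl on a saturated chain carbon bound to an oxygen next to a carbonyl group.

The closest evidence comes from earlier changes at this same chain. The measured steps are a 1.7-fold lower number from compound 1 to compound 2 (0.23 log units; within the scatter) and a 1.1-fold lower number from compound 2 to compound 3 (0.06 log units; within the scatter) and also a 2.0-fold lower number from compound 1 to compound 3 (0.29 log units; within the scatter) across the whole set. Among the measured compounds shown here, none of them leaves the scatter, although no pentyl compound has been tested, so this remains an extrapolation. In this assay the expected step is a 1.1-fold lower number from compound 3 to compound 4 (0.06 log units; within the scatter) and nothing beyond the scatter is anticipated. For compound 4 the estimated value is 850 nM with an expected range from 400 nM to 1800 nM in this estimate.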

Compound 4, half-maximal inhibitory concentration: 4470 nM
The estimate for compound 4 lay 5.3-fold (0.72 log units) below the measured number; measured number above the stated range.
By their numbers in this assay, from the lowest: compounds 3, 2 and 1 (each within the scatter of the next); then compound 4.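

In this assay, among the compounds shown here, the move to a pentyl chain on the oxygen next to a carbonyl group is the first change at this position to go beyond the scatter, and it weakens inhibition: a 4.6-fold higher number from compound 3 to compound 4 (0.66 log units; beyond the scatter), a 4.0-fold higher number from compound 2 to compound 4 (0.60 log units; beyond the scatter) and a 2.3-fold higher number from compound 1 to compound 4 (0.37 log units; beyond the scatter). Compounds 1, 2 and 3 stand level, so this chain tolerates variation up to isobutyl, yet a single further carbon, arranged as an unbranched pentyl chain, makes compound 4 the weakest inhibitor of the four, and the earlier flat steps gave no warning of this. Nothing measured here offers an explanation for this loss of inhibition.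

Isobutyl to pentyl alters both the carbon count and the branching, so the compounds shown cannot separate length from shape; an unbranched butyl chain, or a branched chain of the same size as pentyl, would be needed to tell these apart. On these data alone, whether a longer chain such as hexyl weakens inhibition further, or whether a chain carrying an amine or a carboxylic acid behaves differently, also remains open.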